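The source may hold more compounds than are shown below. What is called first, only, known or untested is meant among the compounds shown, and "the series" means these compounds.

Among the measured compounds shown here, compound 1, with structure `COc1ccc(C(=O)/C=C/c2cn(-c3ccccc3)nc2-c2ccsc2)c(OC)c1OC`, is the weaker of the two compounds measured so far. In a functional assay on MCF7 cells (Homo sapiens) for inhibition, read by sulforhodamine B assay, with a stated time of 72 h (a higher number here means a weaker inhibitor, a lower number a stronger inhibitor), compound 1 gives 7400 nM. Its partner, compound 2 with structure `COc1ccc(C(=O)/C=C/c2cn(-c3ccccc3)nc2-c2ccsc2)cc1OC`, keeps the same core and gives 2800 nM in this assay. For the measured compounds named here, the single change between them, hydrogen in place of methoxy on an aromatic carbon, produced a 2.6-fold lower number from compound 1 to compound 2 (0.42 log units; beyond the scatter), so compound 1 stands at the highest of the two numbers, with compound 2 the nearest and the only other point of comparison.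

The new compound, compound 3 with structure `COc1ccc(C(=O)/C=C/c2cn(-c3ccccc3)nc2-c2cccnc2)c(OC)c1OC`, is built from compound 1 by a different kind of change: pyridin-3-yl in place of thiophen-3-yl on an aromatic carbon. Going by the values given here, no measured step touches this ring; the only step available, that from compound 1 to compound 2, alters the methoxy pattern and says nothing about swapping one small aromatic ring for another. With nothing to lean on, the expectation for compound 3 is a step of no change at the digits printed from compound 1 to compound 3 (within the scatter), that is, no change beyond the scatter. Compound 3 is therefore estimated at 7400 nM in this assay, within a range from 2500 nM to 22000 nM.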

Compound 3, half-maximal inhibitory concentration: 1400 nM
The estimate for compound 3 lay 5.3-fold (0.72 log units) above the measured number; measured number below the stated range.
By their numbers in this assay, from the lowest: compounds 3 and 2 (each within the scatter of the next); then compound 1.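

In this assay, the earlier step showed only that the methoxy pattern matters; this one, a 5.3-fold lower number from compound 1 to compound 3 (0.72 log units; beyond the scatter), shows that the ring on the aromatic carbon next to the ring nitrogen also matters, since the number moves beyond the scatter when pyridin-3-yl replaces thiophen-3-yl. This single swap alters two things at once: a five-membered aromatic ring with a sulfur gives way to a six-membered aromatic ring with a nitrogen, so the step cannot be assigned to ring size or to the hetero atom alone. Nothing measured here accounts for the drop in the number, which remains an observation about these two compounds and has no explanation attached.

A plain phenyl ring at this position, or pyridin-4-yl with its nitrogen placed elsewhere in the ring, would help separate the contribution of ring size from that of the hetero atom. As far as these compounds go, it also remains open whether pyridin-3-yl would give a step of similar size on the core of compound 2, which carries one methoxy group fewer than compound 1.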